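The source may report more compounds than this note shows. Statements on the series, on what has been measured and on what is new or still open speak of the compounds shown alone.

Working notes on the series. In a functional assay on HeLa cells (Homo sapiens) for inhibition, read by CCK-8 assay, with a stated time of 48 h (a lower number here means a stronger inhibitor, a higher number a weaker inhibitor), compound 3 `O=C(Nc1cccc([N+](=O)[O-])c1)N1CCN(S(=O)(=O)c2sccc2-c2ccccc2Oc2ccc(O)c(O)c2)CC1` gives > 20000 nM as a limit and not a number, so its true position is not known. Compound 2 `O=C(NCCNS(=O)(=O)c1ccc(-c2ccccc2O[C@H]2CC[C@H](O)CC2)s1)Nc1cc(C(F)(F)F)cc(C(F)(F)F)c1` gives > 20000 nM as a limit too. Compound 1 `COc1ccc(Oc2ccccc2-c2ccsc2S(=O)(=O)N2CCN(C(=S)Nc3ccc([N+](=O)[O-])cc3)CC2)cc1OC` also carries 3,4-dimethoxyphenoxy and gives > 50000 nM as a limit as well. Among the measured compounds shown here, no measured value falls inside the range of this assay and no measured pair isolates the change now in question.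

Compound 4 `COc1ccc(Oc2ccccc2-c2ccsc2S(=O)(=O)N2CCN(C(=O)Nc3cccc([N+](=O)[O-])c3)CC2)cc1OC` has 3,4-dimethoxyphenyl in place of 3,4-dihydroxyphenyl on an oxygen on an aromatic ring, the counted difference being 3,4-dimethoxyphenyl in place of 3,4-dihydroxyphenyl on an oxygen on an aromatic ring here. With limits alone to go on, no step beyond the scatter is expected in this assay in either direction. The expected step that the limit leaves unreadable from compound 3 to compound 4 is therefore an estimate with little behind it. Another limit is the likeliest report. For compound 4 the estimated value is 30000 nM with an expected range of 12000 nM to 60000 nM as its span.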

Compound 4, half-maximal inhibitory concentration: > 50000 nM
Compound 4 gave a limit, no number; the forecaster's own chance of this, stated with the estimate: 75%; at least 1.6-fold (0.22 log units) between middle value and limit.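

In this assay no step can be read from compound 3 to compound 4 or from compound 1 to compound 4: all three compounds carry limits, not numbers. The compounds shown leave open whether either change, 3,4-dimethoxyphenyl in place of 3,4-dihydroxyphenyl or the exchanged group on the amine nitrogen in a ring, shifts inhibition at all.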